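The source may report more compounds than this note shows. Statements on the series, on what has been measured and on what is new or still open speak of the compounds shown alone.

Three compounds of the series carry numbers in a functional assay on NCI-H1975 cells (Homo sapiens) for antiproliferative activity, read by MTT assay, with a stated time of 72 h; a higher number here means a weaker inhibitor, a lower number a stronger inhibitor. Compound 1 `COc1cc(N(C)CCN(C)C)c(NC(=O)/C=C\C(C)C)cc1Nc1nccc(-c2cn(C)c3ccccc23)n1` gives 1820 nM. Compound 2 `C=C(Cl)C(=O)Nc1cc(Nc2ncc(C#N)c(-c3cn(C)c4ccccc34)n2)c(OC)cc1N(C)CCN(C)C` gives 1620 nM. Compound 3 `CC/C=C\C(=O)Nc1cc(Nc2ncc(C#N)c(-c3cn(C)c4ccccc34)n2)c(OC)cc1N(C)CCN(C)C` gives 1150 nM, the lowest of the three numbers, with compound 2 nearest and compound 1 furthest from it, both within the scatter. Within the data shown here, the single step measured between compounds differing in one place, a 1.4-fold lower number from compound 2 to compound 3 (0.15 log units; within the scatter), exchanges the group on the carbonyl carbon of the amide.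

Compound 4 `COc1cc(N(C)CCN(C)C)c(NC(=O)/C=C\C(C)C)cc1Nc1ncc(C#N)c(-c2cn(C)c3ccccc23)n1` is the next member. Relative to compound 3 the change is methyl in place of hydrogen on a saturated chain carbon bound to a double-bonded chain carbon and a saturated chain carbon. Among the measured compounds shown here, compound 4 carries the same amide as compound 1 and the same core as compound 3; no measured step joins it to compound 1 by a single change, so the values of compound 1 and compound 3 can only be set side by side, and they lie within the scatter of each other. For the measured compounds named here, the step from compound 2 to compound 3, the one measured step that also alters the group on the carbonyl carbon, stayed within the scatter. No step beyond the scatter is therefore expected in this assay for this change, in either direction. For compound 4 the estimated step of a 1.2-fold higher number from compound 3 to compound 4 (0.09 log units; within the scatter) is expected to be small. Compound 4 is expected to give about 1400 nM, in the range 700 nM to 2800 nM.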

Compound 4, half-maximal inhibitory concentration: 1110 nM
The estimate for compound 4 lay 1.3-fold (0.10 log units) above the measured number, within the range that was stated.
By their numbers in this assay, from the lowest: compounds 4, 3, 2 and 1 (each within the scatter of the next).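

Working from this assay, methyl in place of hydrogen on a saturated chain carbon bound to a double-bonded chain carbon and a saturated chain carbon gives a 1.0-fold lower number from compound 3 to compound 4 (0.02 log units; within the scatter) and thus turns out to be a silent change here: on this core, the isopropyl end of the chain reads the same as the ethyl end. Compound 4 also supplies two comparisons the earlier compounds lacked, a 1.5-fold lower number from compound 2 to compound 4 (0.16 log units; within the scatter) for 3-methylbut-1-en-1-yl in place of 1-chloroethenyl on a carbonyl carbon and a 1.6-fold lower number from compound 1 to compound 4 (0.21 log units; within the scatter) for cyano in place of hydrogen on an aromatic carbon, the first reading of that aromatic carbon, so neither the group on the carbonyl carbon nor this cyano has yet moved the number beyond the scatter among these four compounds. No accompanying evidence bears on these results.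

Still open, on these data alone, is whether a dimethylamino group or a cyclopropyl ring on that saturated chain carbon would carry the number beyond the scatter. Equally open, as far as these compounds go, is whether chlorine or trifluoromethyl in place of the cyano on the aromatic carbon would do so.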